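Difluoromethoxy Replaces Pyridylmethylcarbamoyl on the Anilide Ring

The source may hold more compounds than are shown below. What is called first, only, known or untested is meant among the compounds shown, and "the series" means these compounds.

Compound 3 `O=C(NCc1ccncc1)c1ccc(NC(=O)c2cn(Cc3c(F)cccc3F)c3ccc(=O)[nH]c3c2=O)cc1` gives 20 nM in an in vitro assay on Sf21 cells for inhibition of high affinity 3',5'-cyclic-AMP phosphodiesterase 7A (Homo sapiens), read by scintillation proximity assay, with a stated time of 30 min (a lower number here means a stronger inhibitor, a higher number a weaker inhibitor), the lowest of the two numbers recorded. Compound 1 `N#Cc1ccc(NC(=O)c2cn(Cc3c(F)cccc3F)c3ccc(=O)[nH]c3c2=O)cc1` gives 96 nM in this assay, and the step of a 4.8-fold lower number from compound 1 to compound 3 (0.68 log units; beyond the scatter). Compound 2 `O=C(Nc1c(F)cccc1F)c1cn(Cc2c(F)cccc2F)c2ccc(=O)[nH]c2c1=O` reaches only the limit of this assay, > 1000 nM. The step of an at least 10-fold higher number from compound 1 to compound 2 (1.01 log units; beyond the scatter). Compound 4 `O=C(Nc1ccc(OC(F)F)cc1)c1cn(Cc2c(F)cccc2F)c2ccc(=O)[nH]c2c1=O` differs from compound 3 by difluoromethoxy in place of ((pyridin-4-yl)methyl)carbamoyl on an aromatic carbon. Taking the carbamoyl away roughly reverses the gain seen in a 4.8-fold lower number from compound 1 to compound 3 (0.68 log units; beyond the scatter), but difluoromethoxy is not nitrile, and nothing measured tells whether it behaves like it. A modest rise is therefore expected, a 7.5-fold higher number from compound 3 to compound 4 (0.88 log units; beyond the scatter). Compound 4 is estimated at 150 nM, with a likely range from 50 nM to 500 nM.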

Compound 4, half-maximal inhibitory concentration: 71 nM
Beside the measured number, compound 4's estimate is 2.1-fold (0.32 log units) above it, and the stated range covers the measured number.
By their numbers in this assay, from the lowest: compound 3; then compounds 4 and 1 (each within the scatter of the next). At a limit, above all of these: compound 2.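

With a 1.4-fold lower number from compound 1 to compound 4 (0.13 log units; within the scatter), difluoromethoxy and cyano on this aromatic carbon cannot be told apart, while ((pyridin-4-yl)methyl)carbamoyl stays ahead of difluoromethoxy, with a 3.6-fold higher number from compound 3 to compound 4 (0.55 log units; beyond the scatter). The 4-(difluoromethoxy)phenyl group also stands clear of 2,6-difluorophenyl on the amide-type nitrogen, with an at least 14-fold lower number from compound 2 to compound 4 (1.14 log units; beyond the scatter). That step rests on a limit for compound 2, not on a number: the limit of > 1000 nM in this assay, at which 1 of the 4 values shown sits.

The compounds shown leave open whether the lower number of compound 3 needs the pyridine ring or only the carbamoyl. A plain carboxamide or a carboxylic acid on this carbon would separate the two.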